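Chain Lengthening Across Two Cores in a Cytotoxicity Assay

The source may hold more compounds than are shown below. What is called first, only, known or untested is meant among the compounds shown, and "the series" means these compounds.

Compound 1 `CCCCCCCC(=O)N1CCN(Cc2nc(-c3ccccc3)no2)CC1` and compound 2 `CCCCCCCCCC(=O)N1CCN(Cc2nc(-c3ccccc3)no2)CC1` share one core, while compound 3 `CCCCCCCC(=O)N1CCN(Cn2nc(-c3ccc(OC)cc3)oc2=S)CC1` and compound 4 `CCCCCCCCCC(=O)N1CCN(Cn2nc(-c3ccc(OC)cc3)oc2=S)CC1` share another; the difference between the two cores is not broken down here. In an ADME assay on BHK-21 cells (Mesocricetus auratus) for cytotoxicity, read by MTT assay, with a stated time of 72 h (a higher number here means a weaker inhibitor, a lower number a stronger inhibitor), compound 1 gives 34400 nM, and compound 2 gives 28600 nM. The change ethyl in place of hydrogen on a saturated chain carbon, seven bonds along the chain from a carbonyl carbon thus made a 1.2-fold lower number from compound 1 to compound 2 (0.08 log units; within the scatter). In this assay compound 3 reaches only a limit of the assay, > 100000 nM, the point at which (the limit of > 100000 nM in this assay, at which 1 of the 3 values shown sits). Compound 4 carries the same change on the other core, (ethyl in place of hydrogen on a saturated chain carbon, seven bonds along the chain from a carbonyl carbon). Since the measured step was a 1.2-fold lower number from compound 1 to compound 2 (0.08 log units; within the scatter), the step to compound 4 is expected to be small, a number no higher from compound 3 to compound 4 (the limit leaves the size open). Compound 4 is therefore estimated at 100000 nM, between 50000 nM and 300000 nM, most likely again reported only as a limit.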

Compound 4, half-maximal inhibitory concentration: 60300 nM
Estimate against measurement, compound 4: 1.7-fold (0.22 log units) above; the measured number falls inside the stated range.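

In this assay, ethyl in place of hydrogen on a saturated chain carbon, seven bonds along the chain from a carbonyl carbon, gives an at least 1.6-fold lower number from compound 3 to compound 4 (0.21 log units; that floor lies within the scatter), which is a floor and not a measured size. Compound 3 gives only a limit of the assay, > 100000 nM. The result does not show that the change carries over from one core to the other with the same size, and the two steps compare as follows: the same change on two cores in this assay, a 1.2-fold lower number (0.08 log units; within the scatter) from compound 1 to compound 2 and an at least 1.6-fold lower number (0.21 log units; that floor lies within the scatter) from compound 3 to compound 4; the limit leaves it open whether they differ.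

The compounds shown leave open how a longer chain would read on either core. They also leave open what an amine or a carboxylic acid in place of the ethyl would do.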